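Hydroxy to methoxy on the chain of compound 2

The source may hold more compounds than are shown below. What is called first, only, known or untested is meant among the compounds shown, and "the series" means these compounds.

Three analogues carry a terminal oxygen on a saturated chain. Compound 1 `COCCCN1C(/C=C/c2ccc(O)cc2)=CC(=O)CC1c1ccc(O)cc1` gives 99.4% in a functional assay on Caco-2 cells (Homo sapiens) for activation, read by fluorescence, tested at 10 uM; on this read-out lower numbers stand for a stronger effect and higher numbers for a weaker effect at the one concentration tested. Compound 2 `COc1cc(/C=C/C(=O)/C=C(/C=C/c2ccc(O)c(OC)c2)NCCCO)ccc1O` gives 91% in this assay, second highest of the three numbers, with compound 3 `COCCNC(=C\C(=O)/C=C/c1ccc(O)cc1)/C=C/c1ccc(O)cc1` at 89.7% lying nearest and compound 1 furthest; both gaps sit within the usual scatter, so the three read as one level. Compound 4 `COCCCNC(=C\C(=O)/C=C/c1ccc(O)c(OC)c1)/C=C/c1ccc(O)c(OC)c1` is not yet measured. It differs from compound 2 by methyl in place of hydrogen on an oxygen on a saturated carbon. For the measured compounds named here, no pair measured so far differs in only one place, so the size of this change is untested here. Given compounds 1 and 3, which already carry a methoxy-terminated chain, a step no larger than the scatter is expected, and a number 2 percentage points higher from compound 2 to compound 4 (within the scatter) is the estimate. For compound 4 the expected value in this assay is 93%, between 82% and 104%.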

Compound 4, a percentage reported as activity, at one concentration (the size of the read-out at that concentration, not a potency): 84.8%
The estimate for compound 4 lay 8.2 percentage points above the measured number, within the range that was stated.
By their numbers in this assay, from the lowest: compounds 4, 3, 2 and 1 (each within the scatter of the next, the first and the last beyond it).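

In this assay, for the compounds shown here, hydroxy to methoxy at the end of the saturated chain gives a number 6.2 percentage points lower from compound 2 to compound 4 (within the scatter) as the only single-place reading. A step of this size shows that the read-out stays at one level with either group on this oxygen, so the hydrogen on the chain hydroxy is not needed to hold that level. Nothing available bears on why the step has this size.

Open, going by these compounds, is whether an amine or a carboxylic acid at the chain end would hold the same level. On these data alone, a longer chain is equally open.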